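Series notes: fluoro in place of methoxy

The compounds below may be only part of what the source reports. "The series", "measured", "known", "first", "only" and "open" are said of these compounds alone.

Of the compounds shown here, two have been measured so far in a functional assay on HepG2 cells (Homo sapiens) for inhibition, read by MTT assay, with a stated time of 48 h; on this read-out lower numbers stand for stronger inhibition and higher numbers for weaker inhibition. Compound 1 (`COc1ccc(-n2c(S)nnc2-c2cc(OC)c(OC)c(OC)c2)cc1`) gives 57500 nM. Compound 2 (`COc1ccc(C(=O)CSc2nnc(-c3cc(OC)c(OC)c(OC)c3)n2-c2ccc(OC)cc2)cc1`) gives 18100 nM, the lower of the two numbers. Compound 3 (`COc1ccc(-n2c(SCC(=O)c3ccc(F)cc3)nnc2-c2cc(OC)c(OC)c(OC)c2)cc1`) has not yet been measured. It differs from compound 2 by fluoro in place of methoxy on an aromatic carbon, para to a large group, so that ((4-methoxyphenyl)carbonyl)methyl becomes ((4-fluorophenyl)carbonyl)methyl.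

For the measured compounds named here, only one measured step bears on this change, and only indirectly. Placing the whole ((4-methoxyphenyl)carbonyl)methyl group in place of hydrogen on a sulfur gave a 3.2-fold lower number from compound 1 to compound 2 (0.50 log units; beyond the scatter), a modest step, though beyond the scatter. Going by the values given here, no measured pair tests the substituent on that group alone, so the data support no direction. Given that modest step for the whole group, exchanging one substituent on it is expected to produce a smaller step, probably within the scatter. The expected step is a 1.1-fold lower number from compound 2 to compound 3 (0.05 log units; within the scatter). For compound 3 the estimated value in this assay is 16000 nM, with an expected range of 7000 nM to 38000 nM.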

Compound 3, half-maximal inhibitory concentration: 10700 nM
Estimate against measurement, compound 3: 1.5-fold (0.17 log units) above, within the range that was stated.
By their numbers in this assay, from the lowest: compounds 3 and 2 (each within the scatter of the next); then compound 1.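

In this assay the substituent on the side chain is now tested on its own, and fluoro in place of methoxy gives a 1.7-fold lower number from compound 2 to compound 3 (0.23 log units; within the scatter), so compound 2 and compound 3 cannot be told apart and this position accepts either group with no change that stands clear of the scatter. The side chain keeps its effect with fluoro, giving a 5.4-fold lower number from compound 1 to compound 3 (0.73 log units; beyond the scatter) beside a 3.2-fold lower number from compound 1 to compound 2 (0.50 log units; beyond the scatter), so the step away from hydrogen on the sulfur does not rest on the methoxy group alone. No measurement in hand offers an explanation for any of these steps.

Open, from the compounds shown here alone, is whether the carbonyl or the length of the chain carries the step from hydrogen on the sulfur, which a longer chain or a simple benzyl group on the sulfur would address. Also open is how far this position reaches beyond methoxy and fluoro, for instance with an amine or a carboxylic acid in their place, and the shared core stays the same throughout the compounds shown.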